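This account rests on a few compounds, and the source may have more. Where it says the series, first, only, none or still open, it means among the compounds named here.

Working notes on the series. Of the compounds shown here, three have numbers so far in a functional assay on A2780 cells (Homo sapiens) for inhibition, with a stated time of 72 h, tested at 10 uM; on this read-out lower numbers stand for less inhibition of growth and higher numbers for more inhibition of growth at the one concentration tested. Compound 1 `CC1(C)CCOc2ccc(NC(=O)Nc3ccc(OC(F)(F)F)cc3)cc21` gives 36%. Compound 2 `CCC1(CC)CC(C)(C)Oc2ccc(NC(=S)Nc3ccc([N+](=O)[O-])cc3)cc21` gives 95.7%, the highest of the three numbers. Compound 3 `CCC1(CC)CC(C)(C)Oc2ccc(NC(=O)Nc3ccc([N+](=O)[O-])cc3)cc21` gives 93.7%, a number within the scatter of compound 2, so no order is drawn between the two. Compound 1 lies far beneath compound 2, beyond the scatter, but it differs from compound 2 in more than one place, so no single step can be read from that gap.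

Compound 4 `CCC1(CC)CC(C)(C)Oc2ccc(NC(=S)Nc3ccc(C(F)(F)F)cc3)cc21` is not yet measured. It differs from compound 2 in one place: trifluoromethyl in place of nitro on an aromatic carbon. For the measured compounds named here, no measured pair shows this exchange, so its size is not known from the data. Going by the values given here, the only compound without a nitro group, compound 1, carries a different core and a different group and sits low with 36%, which gives weak grounds for expecting a drop rather than a rise. The step from compound 2 to compound 4 is estimated as a number 25.7 percentage points lower from compound 2 to compound 4 (beyond the scatter), a decrease beyond the scatter, though with wide uncertainty. For compound 4 the expected value is 70%, within a range from 35% to 95%.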

Compound 4, percent growth inhibition at one concentration: 11.8%
Beside the measured number, compound 4's estimate is 58.2 percentage points above it; the measured number lies below the stated range.
By their numbers in this assay, from the lowest: compound 4; then compound 1; then compounds 3 and 2 (each within the scatter of the next).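

In this assay, for the compounds shown here, trifluoromethyl in place of nitro on an aromatic carbon, para to a large group, gives a number 83.9 percentage points lower from compound 2 to compound 4 (beyond the scatter), the only step that can be read at a single place. This one exchange shows that the rest of compound 2, kept unchanged in compound 4, is not enough to hold the high number, and that the group at this position can decide between strong and weak growth inhibition at the one concentration tested. Nothing in the data on hand explains why these two groups part so widely.

From the compounds shown here alone, with only nitro and trifluoromethyl compared at this carbon, it remains open whether nitro is a rare solution or whether a nitrile, an amine or a carboxylic acid in the same place would also give a high number. Going by these compounds, it also remains open whether the same exchange has a step of similar size in compound 3, where the rest of the molecule differs from compound 2 by a carbonyl in place of a thiocarbonyl.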